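The source may report more compounds than this note shows. Statements on the series, on what has been measured and on what is new or still open speak of the compounds shown alone.

The account concerns three compounds tested in an assay on MCF7 cells for inhibition of Serine-protein kinase ATM (Homo sapiens), read by immunofluorescence, with a stated time of 1 h (a lower number here means a stronger inhibitor, a higher number a weaker inhibitor), and a fourth that awaits measurement. Compound 1 `Nc1cc2c(-n3nc(-c4ccccn4)nc3N)ncnc2cc1Cl` gives > 40000 nM in this assay, which is a limit of the assay rather than a number. Compound 2 `Nc1nc(-c2ccccn2)nn1-c1ncnc2cc(OC(F)(F)F)ccc12` likewise reaches only a limit in this assay, recorded as > 40000 nM. Compound 3 `COc1cc2nc(Cl)nc(-n3nc(-c4ccccn4)nc3N)c2cc1OC` also stands at a limit in this assay, namely > 40000 nM. Compound 3 therefore has no measured figure to stand on: the limit of > 40000 nM in this assay, at which 3 of the 3 values shown sit, so nothing separates the three. Compound 4 `COc1cc2nc(N)nc(-n3nc(-c4ccccn4)nc3N)c2cc1OC` has not yet been measured in this assay. It differs from compound 3 in one place, (amino in place of chloro on an aromatic carbon), that is, amino in place of chloro on an aromatic carbon. For the measured compounds named here, no step between measured compounds exists to gauge such a change, so its size cannot be read from the data. The step expected in this assay is an at least 1.1-fold lower number from compound 3 to compound 4 (0.05 log units; that floor lies within the scatter), a change estimated to stay within the scatter. Compound 4 is accordingly estimated at 35000 nM in this assay, with a range from 6000 nM to 150000 nM, and a fair chance that only a limit is reported once more.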

Compound 4, half-maximal inhibitory concentration: 2100 nM
Compound 4: middle estimate off by 17-fold (1.22 log units), on the high side; the measured number lies below the stated range.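

In this assay, amino in place of chloro on an aromatic carbon, at the place between two ring nitrogen atoms, gives an at least 19-fold lower number from compound 3 to compound 4 (1.27 log units; beyond the scatter), which shows that the read-out responds strongly to this one exchange at this position. Compound 3 has > 40000 nM, which is a limit of the assay and not a number, so the step gives only a floor and its full size cannot be read. Compound 4 supplies the only measured figure among the compounds shown, and the others give no number to compare it with: the limit of > 40000 nM in this assay, at which 3 of the 4 values shown sit.

The compounds shown do not tell whether a methylamino group, a hydroxyl group or a plain hydrogen at this place would match amino. They also leave open whether an amino group at this place would give a similar step on the core of compound 1 or compound 2.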